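Moving the Chlorine Around the Benzoyl Ring

A few compounds are considered here, and "the series" means these few. Any claim that something is new, unique, unknown or untested is made for them only; others in the source may bear on it.

Measured so far:
- Compound 1 `Cc1ccc(OCC(=O)NNC(=O)c2cc3ccccc3oc2=O)c(C(=O)c2cccc(Cl)c2)c1` gives 65500 nM in a functional assay on DLA cells (Mus musculus) for cytotoxicity, read by MTT assay, with a stated time of 48 h; on this read-out lower numbers stand for stronger inhibition and higher numbers for weaker inhibition.
- Compound 2 `Cc1ccc(OCC(=O)NNC(=O)c2cc3ccccc3oc2=O)c(C(=O)c2ccccc2Cl)c1` gives 53800 nM in this assay.

Within the data shown here, compound 1 stands at the top of these two numbers, yet the only step available, a 1.2-fold lower number from compound 1 to compound 2 (0.09 log units; within the scatter), lies within the scatter. Compound 3 `Cc1ccc(OCC(=O)NNC(=O)c2cc3ccccc3oc2=O)c(C(=O)c2ccc(Cl)cc2)c1` differs from compound 1 by 4-chlorophenyl in place of 3-chlorophenyl on a carbonyl carbon. Among the measured compounds shown here, the one measured step that bears on this, shifting the same chlorine, was small, so no step beyond the scatter is expected in this assay. Compound 3 is therefore expected to give 58000 nM, with a range of 25000 nM to 130000 nM, which would be a step of a 1.1-fold lower number from compound 1 to compound 3 (0.05 log units; within the scatter).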

Compound 3, half-maximal inhibitory concentration: 59100 nM
For compound 3 the middle estimate is 1.0-fold (0.01 log units) below the measured one; low and high end bracket the measured number.
By their numbers in this assay, from the lowest: compounds 2, 3 and 1 (each within the scatter of the next).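

Compound 3 completes the set of chlorine placings on this ring, giving a 1.1-fold lower number from compound 1 to compound 3 (0.04 log units; within the scatter) and a 1.1-fold higher number from compound 2 to compound 3 (0.04 log units; within the scatter) in this assay. Among these compounds, all three compounds therefore lie within the scatter of one another, so among them the place of the chlorine makes no readable difference, which the single earlier step could not show. No measurement at hand offers an explanation for this.

On these data alone, whether this ring responds to anything other than a chlorine remains open. A phenyl without chlorine, or one carrying an amine or a carboxylic acid, would test that.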